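Swapping the five-membered ring on the piperazine arm

This account rests on a few compounds, and the source may have more. Where it says the series, first, only, none or still open, it means among the compounds named here.

Measured compounds in an assay on isolated protein for displacement of a labelled ligand from Gonadotropin-releasing hormone receptor (Homo sapiens); a higher number here means a weaker inhibitor, a lower number a stronger inhibitor:
compound 1 `Cc1nc(CN2CCN(c3cccc4[nH]c(-c5ccc(C(C)(C)C)cc5)nc34)CC2)c[nH]1` gives 7.5 nM
compound 2 `Cc1nc(C)c(CN2CCN(c3cccc4[nH]c(-c5ccc(C(C)(C)C)cc5)nc34)CC2)o1` gives 31 nM
compound 3 `CCc1cc(CN2CCN(c3cccc4[nH]c(-c5ccc(C(C)(C)C)cc5)nc34)CC2)nn1C` gives 43 nM

Compound 3 holds the highest number of the three. Its gap to compound 2 is small, a 1.4-fold higher number from compound 2 to compound 3 (0.14 log units; within the scatter), so these two cannot be told apart; its gap to compound 1 is clear, a 5.7-fold higher number from compound 1 to compound 3 (0.76 log units; beyond the scatter), so compound 1 is the stronger binder of that pair.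

Compound 4 `Cc1nc(CN2CCN(c3cccc4[nH]c(-c5ccc(C(C)(C)C)cc5)nc34)CC2)cn1C` keeps the shared core and changes only the ring hanging from the chain carbon: 1,2-dimethyl-1H-imidazol-4-yl in place of 5-ethyl-1-methyl-1H-pyrazol-3-yl on a saturated chain carbon bound to an amine nitrogen in a ring. The entering group is the group of compound 1 with one additional methyl on the ring nitrogen. The measured step of a 5.7-fold higher number from compound 1 to compound 3 (0.76 log units; beyond the scatter) runs in the opposite direction to that change, so going from compound 3 to compound 4 is close to undoing it, while the pair of steps a 4.1-fold higher number from compound 1 to compound 2 (0.62 log units; beyond the scatter) and a 1.4-fold higher number from compound 2 to compound 3 (0.14 log units; within the scatter) show that the other two five-membered rings both sit well above compound 1.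

Compound 4 is therefore expected to come back toward compound 1, with a step of a 3.3-fold lower number from compound 3 to compound 4 (0.52 log units; beyond the scatter), though the added methyl leaves room for it to fall short. The estimate for compound 4 is 13 nM, with a range from 5 nM to 35 nM.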

Compound 4, half-maximal inhibitory concentration: 10 nM
Compound 4: middle estimate off by 1.3-fold (0.11 log units), on the high side; low and high end bracket the measured number.
By their numbers in this assay, from the lowest: compounds 1 and 4 (each within the scatter of the next); then compounds 2 and 3 (each within the scatter of the next).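

Among the compounds shown here, putting a methyl on the aromatic nitrogen of the 2-methyl-1H-imidazol-4-yl group leaves no step that can be read, a 1.3-fold higher number from compound 1 to compound 4 (0.12 log units; within the scatter), so the hydrogen on that nitrogen is not required for a low number in this set. The 1,2-dimethyl-1H-imidazol-4-yl group still stands clearly apart from the other two rings, a 4.3-fold lower number from compound 3 to compound 4 (0.63 log units; beyond the scatter) and a 3.1-fold lower number from compound 2 to compound 4 (0.49 log units; beyond the scatter), even though the groups of compound 3 and compound 4 have the same hydrogen-bond donor and acceptor counts and the same hetero atoms, so those features alone do not separate them. Nothing measured here gives a reason for these differences.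

On these data alone, it remains open whether that ring nitrogen accepts an ethyl or a longer chain in place of methyl. As far as these compounds go, the effect of a thiazole or a 1,2,4-triazole on the same chain carbon also remains unknown.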